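A few compounds are considered here, and "the series" means these few. Any claim that something is new, unique, unknown or untested is made for them only; others in the source may bear on it.

Measured compounds, with their numbers in a functional assay on HeLa cells (Homo sapiens) for inhibition, read by cell counting, with a stated time of 96 h; on this read-out lower numbers stand for stronger inhibition and higher numbers for weaker inhibition:
compound 1, `CCN(CC)CN1C(=O)/C(=N/NC(=S)Nc2ccc(Cl)cc2)c2ccccc21`, gives 7600 nM;
compound 2, `CCN(CC)CN1C(=O)/C(=N/NC(N)=S)c2cc(Cl)ccc21`, gives 44000 nM;
compound 3, `CCN(CC)CN1C(=O)/C(=N/NC(=S)Nc2ccccc2)c2ccccc21`, gives 8300 nM.

Compound 2 has the highest number of the three, beyond the scatter against both compound 1 and compound 3. Compound 4 is `CCN(CC)CN1C(=O)/C(=N/NC(=S)Nc2ccc(OC)cc2)c2cc(Cl)ccc21`. Its change from compound 2: 4-methoxyphenyl in place of hydrogen on an amide-type nitrogen. Among the compounds with values here, no measured step touches the thiourea nitrogen directly. Within the data shown here, the one measured step, a 1.1-fold higher number from compound 1 to compound 3 (0.04 log units; within the scatter), concerns the aryl substituent and is within the scatter, so it only shows that chloro or hydrogen on that ring matters little. Compound 3 carries the phenyl on that nitrogen and sits well under compound 2, though the two also differ at the core. An aryl group entering on this nitrogen is therefore expected to lower the number in this assay, with the step from compound 2 estimated as a 4.9-fold lower number from compound 2 to compound 4 (0.69 log units; beyond the scatter). Compound 4 is estimated at 9000 nM, range 3000 nM to 27000 nM.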

Compound 4, half-maximal inhibitory concentration: 9200 nM
Compound 4: the middle estimate sits 1.0-fold (0.01 log units) below what was measured, within the range that was stated.
By their numbers in this assay, from the lowest: compounds 1, 3 and 4 (each within the scatter of the next); then compound 2.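

In this assay, within the data shown here, the change to 4-methoxyphenyl in place of hydrogen on the amide-type nitrogen gives a 4.8-fold lower number from compound 2 to compound 4 (0.68 log units; beyond the scatter) and is the first reading at this position with the rest of the structure held constant. The earlier compounds shown here offered only a comparison across different cores, whereas this step shows that the position responds to the change on the core of compound 2. Nothing available explains the size of this step.

Whether the methoxy group contributes to the step remains open, since the unsubstituted phenyl is not shown on this core. Also open, from the compounds shown here alone, is how a non-aromatic group, such as a longer alkyl chain or an amine-bearing chain, would behave on this nitrogen.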